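Adding a Methyl to the Chain of Compound 3

The source may hold more compounds than are shown below. What is called first, only, known or untested is meant among the compounds shown, and "the series" means these compounds.

Measured in a functional assay (plasma) with Oryctolagus cuniculus as the target; on this read-out lower numbers stand for stronger inhibition and higher numbers for weaker inhibition:
- compound 1 `Cc1nc2cnccc2n1C1CCN(C(=O)CC(c2ccccc2)c2ccccc2)CC1`: 100 nM
- compound 2 `COC(=O)NC(CC(=O)N1CCC(n2c(C)nc3cnccc32)CC1)c1ccccc1`: 1300 nM
- compound 3 `Cc1nc2cnccc2n1CC1CCN(C(=O)CC(C)c2ccccc2)CC1`: 12 nM

Of these three, compound 3 has the lowest number, well clear of compound 1 and further still from compound 2. The next structure, compound 4 `Cc1nc2cnccc2n1CC1CCN(C(=O)CC(C)(C)c2ccccc2)CC1`, differs from compound 3 as follows: methyl in place of hydrogen on a saturated chain carbon bound to an aromatic carbon and two saturated chain carbons. Thus 1-phenylethyl becomes 1-methyl-1-phenylethyl. Among the compounds with values here, only one measured step touches this part of the chain, a 13-fold higher number from compound 1 to compound 2 (1.11 log units; beyond the scatter). It was large, but it exchanged phenyl for (methoxycarbonyl)amino, so it says little about an added methyl. Within the data shown here, no measured step shows that change, so only a small shift toward a higher number is expected, not beyond the scatter: a 1.7-fold higher number from compound 3 to compound 4 (0.22 log units; within the scatter). Compound 4 is estimated at 20 nM, with an expected range of 5 nM to 80 nM.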

Compound 4, half-maximal inhibitory concentration: 6.7 nM
The estimate for compound 4 lay 3.0-fold (0.47 log units) above the measured number; the measured number falls inside the stated range.
By their numbers in this assay, from the lowest: compounds 4 and 3 (each within the scatter of the next); then compound 1; then compound 2.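

In this assay, methyl in place of hydrogen on this saturated chain carbon gives a 1.8-fold lower number from compound 3 to compound 4 (0.25 log units; within the scatter), so the two compounds cannot be told apart on this read-out. Going from 1-phenylethyl to 1-methyl-1-phenylethyl therefore leaves the number where it was, something the earlier exchange of phenyl for (methoxycarbonyl)amino could not show. No evidence is available to explain this result. The compounds shown leave open whether ethyl on this carbon would keep the number at this level. They also leave open what an amine or a carboxylic acid there would do.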